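The source may hold more compounds than are shown below. What is called first, only, known or untested is meant among the compounds shown, and "the series" means these compounds.

Compound 1, with the structure `O=C1C=COC(/C=C/c2ccccc2)C1`, was tested in a functional assay on NCI-H460 cells (Homo sapiens) for inhibition, read by sulforhodamine B assay, with a stated time of 48 h (on this read-out higher numbers stand for weaker inhibition of growth and lower numbers for stronger inhibition of growth), where compound 1 gives 82.4 uM. Compound 2, with the structure `O=C1C=COC(/C=C/c2ccc(C(F)(F)F)cc2)C1`, carries one change relative to compound 1, namely (trifluoromethyl in place of hydrogen on an aromatic carbon). In this assay compound 2 gives 95.6 uM, and the step of a 1.2-fold higher number from compound 1 to compound 2 (0.06 log units; within the scatter) is small enough to count as no real difference between the two.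

Compound 3, with the structure `O=C1C=CCC(/C=C/c2ccccc2)N1`, has a different core from compound 1; the difference between the two cores is not broken down here. In this assay, going by the values given here, compound 3 gives 929 uM, the highest of the three numbers so far, and the gaps to compound 1 and to compound 2 are both well beyond the ordinary spread of repeated measurements.

Compound 4, with the structure `O=C1C=CCC(/C=C/c2ccc(C(F)(F)F)cc2)N1`, has not yet been measured. It stands to compound 3 as compound 2 stands to compound 1, through the change (trifluoromethyl in place of hydrogen on an aromatic carbon), which is the same change as before: the place lines agree word for word. Because the earlier step of a 1.2-fold higher number from compound 1 to compound 2 (0.06 log units; within the scatter) was small, the step of a 1.1-fold higher number from compound 3 to compound 4 (0.03 log units; within the scatter) is expected to be small as well, so that compound 4 is expected to stay close to compound 3. On that basis the number for compound 4 in this assay is estimated at 1000 uM, with a plausible range from 400 uM to 2500 uM.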

Compound 4, concentration for growth inhibition (reported as GI): 150 uM
Beside the measured number, compound 4's estimate is 6.7-fold (0.82 log units) above it; measured number outside the range, below it.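

In this assay, placing trifluoromethyl in place of hydrogen on an aromatic carbon of the core of compound 3 gives a 6.2-fold lower number from compound 3 to compound 4 (0.79 log units; beyond the scatter), and on this read-out the lower number stands for stronger inhibition of growth. The size of this change's effect therefore did not carry over from one core to the other, since the same swap made no real difference on the core of compound 1 and the two steps clearly disagree: the same change on two cores in this assay, a 1.2-fold higher number (0.06 log units; within the scatter) from compound 1 to compound 2 and a 6.2-fold lower number (0.79 log units; beyond the scatter) from compound 3 to compound 4, 7.2-fold (0.86 log units) apart, beyond the scatter of two such steps

Going by these compounds alone, this does not show why the two cores respond differently, and with only one pair of compounds on each core it gives no general rule for how other changes will transfer.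

The compounds shown carry only hydrogen or trifluoromethyl at this place on the aromatic ring, so it remains open whether a methoxy group, an amine or a carboxylic acid there would also behave differently on the two cores. Also open, going by these compounds, is which part of the difference between the cores matters, as compound 1 and compound 3 differ in more than a single feature that could be examined on its own here.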